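A few compounds are considered here, and "the series" means these few. Any claim that something is new, unique, unknown or untested is made for them only; others in the source may bear on it.

Working notes on the dithiocarbonate series. In an assay on HEK293 cells for inhibition of protein deacetylase HDAC6 (Homo sapiens) (a lower number here means a stronger inhibitor, a higher number a weaker inhibitor), compound 1 `CCSC(=S)SCC(=O)c1cccc(C(=O)Nc2ccccc2)c1` gives 517 nM, and compound 2 `COCCSC(=S)SCC(=O)c1ccc(OC)cc1` gives 2130 nM, the higher of the two numbers, with the gap between them beyond the usual scatter. Compound 3 `COc1ccc(C(=O)CSC(=S)SCCOc2ccccc2)cc1` differs from compound 2 in one place: phenyl in place of methyl on an oxygen on a saturated carbon. Among the measured compounds shown here, no measured pair isolates this change. The step of a 1.4-fold lower number from compound 2 to compound 3 (0.15 log units; within the scatter) is expected to stay small, with a slight lean toward a lower number. Compound 3 is therefore estimated at 1500 nM, within 500 nM to 4500 nM.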

Compound 3, half-maximal inhibitory concentration: 4570 nM
Compound 3: middle estimate off by 3.0-fold (0.48 log units), on the low side; measured number above the stated range.
By their numbers in this assay, from the lowest: compound 1; then compound 2; then compound 3.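

In this assay the change from methoxy to phenoxy brings a 2.1-fold higher number from compound 2 to compound 3 (0.33 log units; beyond the scatter) and so shows that this place on the chain is not indifferent to the change: phenyl on this oxygen gives weaker inhibition than methyl, by a modest step resting on this one pair. Nothing at hand explains the step.

On these data alone, whether the same step would appear on the core of compound 1 stays open. Also open, as far as these compounds go, is how an amine or a carboxylic acid in place of methoxy would read.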